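The compounds below may be only part of what the source reports. "The series", "measured", "known", "first", "only" and "open" are said of these compounds alone.

Measured in a functional assay on A549 cells (Homo sapiens) for antiproliferative activity, read by MTT assay, with a stated time of 48 h; a higher number here means a weaker inhibitor, a lower number a stronger inhibitor:
- Compound 1 `Cn1cc(-c2cnc3ccc(NS(=O)(=O)c4ccc(C(F)(F)F)cc4)nc3c2)cn1`: > 50000 nM (a limit)
- Compound 2 `Cn1cc(-c2cnc3ccnc(NC(=O)C4CC4)c3c2)cn1`: > 50000 nM (a limit)
- Compound 3 `Cn1cc(-c2cnc3ccnc(NC(=O)c4ccc(F)cc4)c3c2)cn1`: > 50000 nM (a limit)

Compound 2 is known only through a limit, > 50000 nM, and it shares this position with the others: the limit of > 50000 nM in this assay, at which 3 of the 3 values shown sit. Compound 4 `Cn1cc(-c2cnc3ccnc(NCc4ccc(F)cc4)c3c2)cn1` differs from compound 2 in one place: 4-fluorobenzyl in place of cyclopropylcarbonyl on a nitrogen on an aromatic ring. For the measured compounds named here, the one measured step that bears on this, a step that the two limits leave unreadable from compound 2 to compound 3, puts 4-fluorophenyl in place of cyclopropyl on a carbonyl carbon, and it offers no size to carry over. No step beyond the scatter is therefore expected in this assay, and no direction can be given. The expected step is a number no higher from compound 2 to compound 4 (the limit leaves the size open). For compound 4 the estimated value is 50000 nM, with an expected range from 12000 nM to 100000 nM.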

Compound 4, half-maximal inhibitory concentration: 5200 nM
For compound 4 the middle estimate is 9.6-fold (0.98 log units) above the measured one, and the stated range ends above it.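

In this assay, the nitrogen on an aromatic ring proves to be a place where a change can register: 4-fluorobenzyl in place of cyclopropylcarbonyl gives an at least 9.6-fold lower number from compound 2 to compound 4 (0.98 log units; beyond the scatter). The 4-fluorophenyl on a carbonyl carbon does not suffice, since compound 3 gives > 50000 nM, which is a limit, and its step from compound 2 cannot be read. Compound 4 is the only compound shown with a value that is not a limit, and the others remain at: the limit of > 50000 nM in this assay, at which 3 of the 4 values shown sit.

From the compounds shown here alone, it remains open whether the fluorine contributes to this value. Going by these compounds, how an unsubstituted benzyl or a longer chain such as phenethyl on this nitrogen would read in this assay also remains open.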